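Sulfonyl aryl variation in a shared-core series

A few compounds are considered here, and "the series" means these few. Any claim that something is new, unique, unknown or untested is made for them only; others in the source may bear on it.

Compound 1 `CN1CCN(c2ccc3[nH]nc(S(=O)(=O)c4ccccc4Cl)c3c2)CC1` is the reference. In an assay on HeLa cells for displacement of a labelled ligand from 5-hydroxytryptamine receptor 6 (Homo sapiens) (on this read-out lower numbers stand for stronger inhibition and higher numbers for weaker inhibition), compound 1 gives 4 nM, the lowest of the three numbers measured. Compound 3 `O=S(=O)(c1cccc2ccccc12)c1n[nH]c2cc(N3CCNCC3)ccc12` sits nearest: in this assay compound 3 gives 22 nM, a gap beyond the scatter. Compound 2 `COc1ccc(S(=O)(=O)c2n[nH]c3cc(N4CCNCC4)ccc23)cc1` is furthest; in this assay compound 2 gives 124 nM. Among the compounds with values here, no two measured compounds differ in only one place, so no single step has been measured. Compound 4 `CN1CCN(c2ccc3[nH]nc(S(=O)(=O)c4ccc(F)cc4)c3c2)CC1` differs from compound 1 in one place: 4-fluorophenyl in place of 2-chlorophenyl on a sulfonyl sulfur. Both groups have the same count of heavy atoms and no hydrogen-bond donors or acceptors, yet compound 2 and compound 3 show that the group on the sulfonyl sulfur can move the number well beyond the scatter. The expected step from compound 1 to compound 4 is a 3.0-fold higher number from compound 1 to compound 4 (0.48 log units; beyond the scatter), a modest loss. Compound 4 is estimated at 12 nM in this assay, within 3 nM to 50 nM.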

Compound 4, inhibition constant: 5.2 nM
Beside the measured number, compound 4's estimate is 2.3-fold (0.36 log units) above it, and the stated range covers the measured number.
By their numbers in this assay, from the lowest: compounds 1 and 4 (each within the scatter of the next); then compound 3; then compound 2.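

In this assay, within the data shown here, the one measured single change at this place is a 1.3-fold higher number from compound 1 to compound 4 (0.11 log units; within the scatter): with the rest of compound 1 held fixed, 2-chlorophenyl and 4-fluorophenyl on the sulfonyl sulfur are not told apart. Compound 2 and compound 3 differ from compound 1 in more than one place, so they do not isolate the group on the sulfur. No measured property bears on this result.

Still open, as far as these compounds go, is how a phenyl ring carrying a carboxylic acid or an aminomethyl group in place of the halogen would read in this assay.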